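This account rests on a few compounds, and the source may have more. Where it says the series, first, only, none or still open, it means among the compounds named here.

Compound 1, `COc1cc(NC(=O)Nc2ccccn2)cc(-c2cccnc2)c1OC`, is measured in a functional assay on SMMC-7721 cells (Homo sapiens) for inhibition, read by MTT assay, with a stated time of 48 h (on this read-out higher numbers stand for weaker inhibition and lower numbers for stronger inhibition), where compound 1 gives 22400 nM. Compound 2, `COc1ccc(-c2cc(NC(=O)Nc3ccccn3)cc(OC)c2OC)cn1`, differs from compound 1 by methoxy in place of hydrogen on an aromatic carbon, and in this assay compound 2 gives 32900 nM, a step of a 1.5-fold higher number from compound 1 to compound 2 (0.17 log units; within the scatter). Compound 3, `O=C(Nc1cc(-c2cccnc2)cc(C(F)(F)F)c1)Nc1nccs1`, carries a different core, and the difference between the two cores is not broken down here; in this assay compound 3 gives 68200 nM, the highest number of the three. Compound 4, `COc1ccc(-c2cc(NC(=O)Nc3nccs3)cc(C(F)(F)F)c2)cn1`, has not yet been measured; it differs from compound 3 by methoxy in place of hydrogen on an aromatic carbon, the same change that turns compound 1 into compound 2, made at the same place. The step from compound 3 to compound 4 is expected to be a 1.3-fold higher number from compound 3 to compound 4 (0.12 log units; within the scatter), because the earlier step of a 1.5-fold higher number from compound 1 to compound 2 (0.17 log units; within the scatter) was within the scatter. Compound 4 is therefore estimated to give about 90000 nM, between 40000 nM and 200000 nM.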

Compound 4, half-maximal inhibitory concentration: 36200 nM
Compound 4: middle estimate off by 2.5-fold (0.40 log units), on the high side, outside the stated range (below it).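

In this assay the change from pyridin-3-yl to 6-methoxypyridin-3-yl gives a 1.9-fold lower number from compound 3 to compound 4 (0.28 log units; within the scatter). Set beside the earlier step, the change does not carry over unchanged from one core to the other: the same change on two cores in this assay, a 1.5-fold higher number (0.17 log units; within the scatter) from compound 1 to compound 2 and a 1.9-fold lower number (0.28 log units; within the scatter) from compound 3 to compound 4, 2.8-fold (0.44 log units) apart, beyond the scatter of two such steps. This comparison rests on a single pair on each core, and it does not show which part of the cores lies behind the gap, as the two cores differ in more than one place.

The compounds shown leave open how an ethoxy group or an amine would behave at the same place on the ring. They also leave open what the methoxy change would do on a core that keeps the trifluoromethyl group but shares the rest of the core of compound 1.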